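The source may hold more compounds than are shown below. What is called first, only, known or untested is meant among the compounds shown, and "the series" means these compounds.

Compound 2 `CCOC(=O)COc1ccc2c(=O)c(-c3ccc(O)cc3)coc2c1` shows the lowest number of the two compounds measured in an assay (Cricetulus griseus) for inhibition of aldehyde dehydrogenase, mitochondrial (Homo sapiens); a higher number here means a weaker inhibitor, a lower number a stronger inhibitor: compound 2 gives 130 nM, while compound 1 `CCOC(=O)CCCCCOc1ccc2c(=O)c(-c3ccc(O)cc3)coc2c1` gives 280 nM. Among the compounds with values here, the only measured step, a 2.2-fold lower number from compound 1 to compound 2 (0.33 log units; beyond the scatter), came from shortening the chain that carries the ester, so a shorter chain went with a stronger inhibitor there. Compound 3 `CCOc1ccc2c(=O)c(-c3ccc(O)cc3)coc2c1` goes one step further and drops the ester altogether: methyl in place of ethoxycarbonyl on a saturated chain carbon bound to an oxygen on an aromatic ring. Within the data shown here, no measured step removes the ester, so the trimming step is the only guide, and because a 2.2-fold lower number from compound 1 to compound 2 (0.33 log units; beyond the scatter) was modest, compound 3 is expected to stay near compound 2 in this assay, with the step of a 1.2-fold higher number from compound 2 to compound 3 (0.06 log units; within the scatter) estimated to be within the scatter. The estimate for compound 3 in this assay is 150 nM, with a range from 60 nM to 400 nM.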

Compound 3, half-maximal inhibitory concentration: 80 nM
Beside the measured number, compound 3's estimate is 1.9-fold (0.27 log units) above it, within the range that was stated.
By their numbers in this assay, from the lowest: compounds 3 and 2 (each within the scatter of the next); then compound 1.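

In this assay taking away the ethoxycarbonyl group altogether, leaving a methyl on this saturated chain carbon, gives a 1.6-fold lower number from compound 2 to compound 3 (0.21 log units; within the scatter) and so the ester is not needed to keep this level of inhibition. Measured against the longest chain, the plain ethoxy group gives a 3.5-fold lower number from compound 1 to compound 3 (0.54 log units; beyond the scatter) and so the end of the series with the least chain is clearly separated from the end with the most, even though its two nearest members are not separated from each other. No measurement available here explains why these numbers move as they do.

Still open, going by these compounds, is whether a carboxylic acid in place of the ester, or an amine at the end of the chain, would keep this inhibition. Also open, on these data alone, is how a methoxy group, shorter than the ethoxy group of compound 3, would compare.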